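The compounds below may be only part of what the source reports. "The series", "measured", "known", "first", "only" and "open" are said of these compounds alone.

Of the compounds shown here, two have so far been tested in a functional assay on A-375 cells (Homo sapiens) for antiproliferative activity, read by CCK-8 assay, with a stated time of 72 h, tested at 2 uM; on this read-out higher numbers stand for a stronger effect at the one concentration tested and lower numbers for a weaker effect. Compound 1 `N#Cc1ccc(N2CCN(C(=S)SCc3ccc(C(=O)Nc4ccccc4N)cc3)CC2)cc1` gives 41.4% in this assay. Compound 2 `CCN(Cc1ccncc1)C(=S)SCc1ccc(C(=O)Nc2ccccc2N)cc1` gives 67.2% in this assay, so compound 1 stands lowest of the two numbers, with compound 2 the nearest and its number higher by more than the usual scatter. Compound 3 `Nc1ccccc1NC(=O)c1ccc(CSC(=S)N2CCN(c3cnccn3)CC2)cc1` has not yet been measured. It differs from compound 1 in one place: pyrazin-2-yl in place of 4-cyanophenyl on an amine nitrogen in a ring. The group that leaves carries one six-membered aromatic ring of carbon only and 1 hydrogen-bond acceptor; the group that enters carries one six-membered aromatic ring with 2 hetero atoms and 2 hydrogen-bond acceptors. Among the measured compounds shown here, no measured pair in this set shows such a change, so its effect is unknown. For compound 3 the expected step is a number 3.6 percentage points higher from compound 1 to compound 3 (within the scatter), most likely none beyond the scatter. Compound 3 is therefore estimated at 45%, within a range from 25% to 65% in this assay.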

Compound 3, a percentage reported as inhibition, at one concentration (the size of the read-out at that concentration, not a potency): 29.1%
The estimate for compound 3 lay 15.9 percentage points above the measured number, within the range that was stated.
By their numbers in this assay, from the lowest: compound 3; then compound 1; then compound 2.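

Among the compounds shown here, the comparison of compound 1 and compound 3 in this assay gives the first step at this amine nitrogen in a ring: a number 12.3 percentage points lower from compound 1 to compound 3 (beyond the scatter). With the rest of the structure unchanged, the group on this nitrogen therefore matters, and here pyrazin-2-yl gives a weaker effect at the one concentration tested than 4-cyanophenyl. No measurement available here bears on the reason for this step.

The two groups differ both in the nitrile and in the ring nitrogens, so the compounds shown leave open which of these differences goes with the step. Going by these compounds, how a plain phenyl or a pyridin-2-yl group on the same nitrogen would compare also remains open, and either one would help to separate those two differences.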